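The source may report more compounds than this note shows. Statements on the series, on what has been measured and on what is new or still open speak of the compounds shown alone.

Measured compounds in this set:

compound 1 `NC(=O)c1c(NC(=O)c2ccccc2Cl)sc2c1CCN(Cc1ccccc1F)C2` — in a functional assay on HeLa cells (Homo sapiens) for antiproliferative activity, with a stated time of 24 h (on this read-out lower numbers stand for stronger inhibition and higher numbers for weaker inhibition), compound 1 gives > 50000 nM, a limit of the assay, not a number.
compound 2 `NC(=O)c1c(NC(=O)c2ccc(C(F)(F)F)cc2)sc2c1CCN(Cc1ccccc1F)C2` — in this assay compound 2 gives > 50000 nM, again a limit of the assay.
compound 3 `NC(=O)c1c(NC(=O)c2ccccc2F)sc2c1CCN(Cc1cccc(Cl)c1)C2` — in this assay compound 3 gives 49500 nM.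

Compound 1 therefore stands at the limit of > 50000 nM in this assay, at which 2 of the 3 values shown sit; only compound 3 gives an actual number, and that number lies close to the limit itself. Within the data shown here, the single step between measured neighbours, a step that the two limits leave unreadable from compound 1 to compound 2, is unreadable, since both ends are limits. Compounds 1 and 3 differ in two places at once, so no step can be read from that pair either.

Compound 4 `CSc1ccccc1NC(=S)N1CCc2c(sc(NC(=O)c3ccccc3Cl)c2C(N)=O)C1` differs from compound 1 in a group of 11 heavy atoms (8 carbon, 1 nitrogen, 2 sulfur; one six-membered aromatic ring of carbon only) in place of a group of 8 heavy atoms (7 carbon, 1 fluorine; one six-membered aromatic ring of carbon only), on an amine nitrogen in a ring. Among the measured compounds shown here, no measured step touches the amine nitrogen in the ring; every change so far sits on the carbonyl carbon of the amide, and none of those changes yielded a readable step. There is thus nothing in the data to support a move in either direction.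

The expectation for compound 4 is weak inhibition, at or near the limit, with a step that the limit leaves unreadable from compound 1 to compound 4 estimated as no step beyond the scatter. Compound 4 is estimated at 60000 nM, with a range of 20000 nM to 200000 nM.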

Compound 4, half-maximal inhibitory concentration: 43600 nM
For compound 4 the middle estimate is 1.4-fold (0.14 log units) above the measured one; measured number inside the range.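

In this assay, among these compounds, replacing the 2-fluorobenzyl group with the group of 11 heavy atoms (8 carbon, 1 nitrogen, 2 sulfur) on the amine nitrogen in a ring gives the first step at this position: an at least 1.1-fold lower number from compound 1 to compound 4 (0.05 log units; that floor lies within the scatter). From the compounds shown here alone, compound 1 gives a limit of the assay and not a number, so this step is only a floor, and its true size stays unknown. With the 2-chlorophenyl amide unchanged, compound 4 shows that the read-out can be brought to a measured number through a change at this nitrogen, yet the series remains at the weak end of the range: the limit of > 50000 nM in this assay, at which 2 of the 4 values shown sit.

Only this one replacement stands at the amine nitrogen, and it does not tell which part of the entering group matters, whether the aromatic ring, its sulfur-bearing substituent or the double bond outside the ring. Going by these compounds, whether a small acetyl group or a chain ending in a carboxylic acid on that nitrogen would move the number well away from the limit remains open.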